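Aziridinylquinone side chain: from dimethylcarbamoylethyl to isopropyl

The source may hold more compounds than are shown below. What is called first, only, known or untested is meant among the compounds shown, and "the series" means these compounds.

Three measured compounds share one core and differ in the groups on its double-bonded ring carbons. Compound 1 `CC1=C(N2CC2)C(=O)C(CCC(=O)N(C)C)=C(N2CC2)C1=O` was tested in a functional assay on L1210 cells (Mus musculus), with a stated time of 1 days (a lower number here means a less potent compound, a higher number a more potent compound, by a factor of ten per unit of this negative logarithm), and compound 1 gives 4.84, the highest of the three numbers. Compound 3 `CCOC(COC(N)=O)C1=C(N2CC2)C(=O)C(C)=C(N2CC2)C1=O` gives 4.62 in this assay, a number within the usual scatter of that of compound 1, so the two cannot be told apart. Compound 2 `CCCC1=C(N2CC2)C(=O)C(CCOC(N)=O)=C(N2CC2)C1=O` gives 4.42 in this assay, a number beyond the scatter below that of compound 1. No two of these compounds differ in only one place, so no single step can be read off.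

Compound 4 `CC1=C(N2CC2)C(=O)C(C(C)C)=C(N2CC2)C1=O` has not yet been measured. Its difference from compound 1 is isopropyl in place of 2-(dimethylcarbamoyl)ethyl on a double-bonded ring carbon. Among the compounds with values here, the record holds no pair in which only such a chain is exchanged, so the size of the step has to be estimated rather than read. Since the nearest comparison, compound 1, gives 4.84 in this assay, compound 4 is expected to stay close to it, with a step from compound 1 to compound 4 of a number 0.14 log units lower from compound 1 to compound 4 (within the scatter) that is not expected to exceed the scatter. The value estimated for compound 4 in this assay is 4.7, within a range from 4.1 to 5.3.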

Compound 4, logarithm of the reciprocal of the active concentration, log(1/C): 4.69
For compound 4 the middle estimate is 0.01 log units above the measured one; measured number inside the range.
By their numbers in this assay, from the lowest: compounds 2, 3, 4 and 1 (each within the scatter of the next, the first and the last beyond it).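

In this assay, within the data shown here, the exchange of 2-(dimethylcarbamoyl)ethyl for isopropyl gives a number 0.15 log units lower from compound 1 to compound 4 (within the scatter) and is the first step that changes a single place, so compound 1 and compound 4 cannot be told apart. On this double-bonded ring carbon, next to the ring atom that bears an aziridin-1-yl group, the chain with its 7 heavy atoms, including a nitrogen and an oxygen, can therefore be replaced by 3 carbons without a difference this read-out can resolve. Nothing measured here explains this result.

Compound 2 and compound 3 each differ from compound 1 and from compound 4 in more than one place, so their steps cannot be read, and the effect of the carbamate-bearing chains on this position remains unseparated from that of the other changes. From the compounds shown here alone, it also remains open whether this tolerance extends to a chain ending in an amine or a carboxylic acid, to a longer alkyl chain, or to a plain hydrogen on this ring carbon.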